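Symmetric keto-diols: trimming one arm by a carbon

The source may hold more compounds than are shown below. What is called first, only, known or untested is meant among the compounds shown, and "the series" means these compounds.

Measured so far:
compound 1 `CC(C)(CO)CCCCC(=O)CCCCC(C)(C)CO` – 4000 nM
compound 2 `CC(C)(CO)CCCCCC(=O)CCCCCC(C)(C)CO` – 3000 nM

In a functional assay on cells (Hepatocyte, Rattus norvegicus) for inhibition (on this read-out lower numbers stand for stronger inhibition and higher numbers for weaker inhibition), compound 1 gives 4000 nM and compound 2 gives 3000 nM. Compound 2 stands at the smaller of the two numbers, but its gap to compound 1 lies within the scatter, so the pair shows no real separation. Compound 3 `CC(C)(CO)CCCCCC(=O)CCCCC(C)(C)CO` is not yet measured; it differs from compound 2 by 1-(hydroxymethyl)-1-methylethyl in place of 2-(hydroxymethyl)-2-methylpropyl on a saturated chain carbon, four bonds along the chain from a carbonyl carbon. For the measured compounds named here, no step between measured compounds is known, so the expectation rests on the two values alone. For compound 3 no step beyond the scatter is expected, a 1.2-fold higher number from compound 2 to compound 3 (0.07 log units; within the scatter). Compound 3 is estimated at 3500 nM, range 1500 nM to 8000 nM.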

Compound 3, half-maximal inhibitory concentration: 2000 nM
The estimate for compound 3 lay 1.8-fold (0.24 log units) above the measured number; the range from low to high includes it.
By their numbers in this assay, from the lowest: compounds 3, 2 and 1 (each within the scatter of the next).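

In this assay, the change to 1-(hydroxymethyl)-1-methylethyl in place of 2-(hydroxymethyl)-2-methylpropyl gives a 1.5-fold lower number from compound 2 to compound 3 (0.18 log units; within the scatter), while the reverse change on the other arm gives a 2.0-fold lower number from compound 1 to compound 3 (0.30 log units; within the scatter). Compound 3, with arms of unequal length, therefore does not separate from either symmetric compound, so shortening or lengthening one arm at this position has no readable effect here. No measurement bearing on the cause of these small steps is available.

Still open, going by these compounds, is whether a carboxylic acid in place of the terminal hydroxymethyl, or a much longer chain, would give a step beyond the scatter.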